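Forecast for Compound 4 after a Linker Change

The source may hold more compounds than are shown below. What is called first, only, known or untested is meant among the compounds shown, and "the series" means these compounds.

Measured compounds in a functional assay on HeLa cells (Homo sapiens) for cytotoxicity, read by sulforhodamine B assay, with a stated time of 48 h; a higher number here means a weaker inhibitor, a lower number a stronger inhibitor:
compound 1 `O=c1cc(-c2ccccc2)oc2cc(OCCCCNc3nc4ccccc4s3)cc(O)c12` gives 4.75 ug/mL
compound 2 `O=c1cc(-c2ccccc2)oc2cc(OCCCCNc3nc4ccc(Br)cc4s3)cc(O)c12` gives 6.56 ug/mL
compound 3 `O=c1cc(-c2ccccc2)oc2cc(OCCCCNc3nc4c(F)cc(F)cc4s3)cc(O)c12` gives 5.56 ug/mL

Compound 3 stands second highest of these three numbers; compound 1 is nearest (a 1.2-fold higher number from compound 1 to compound 3 (0.07 log units; within the scatter)) and compound 2 furthest (a 1.2-fold lower number from compound 2 to compound 3 (0.07 log units; within the scatter)), both within the scatter. Compound 4 `O=c1cc(-c2ccccc2)oc2cc(OCCCCNNc3nc4ccccc4s3)cc(O)c12` differs from compound 3 in one place: (1,3-benzothiazol-2-yl)amino in place of 4,6-difluoro-1,3-benzothiazol-2-yl on an amine nitrogen. Among the compounds with values here, the measured steps (a 1.4-fold higher number from compound 1 to compound 2 (0.14 log units; within the scatter), a 1.2-fold higher number from compound 1 to compound 3 (0.07 log units; within the scatter)) concern only substituents on the aromatic rings of that group and all fall within the scatter; no measured step tests a change at the linker itself, so the forecast carries added uncertainty. A step in this assay beyond the scatter is not expected. For compound 4 the estimate is 5.5 ug/mL (range 2.5 ug/mL to 12 ug/mL), an expected 1.0-fold lower number from compound 3 to compound 4 (0.00 log units; within the scatter).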

Compound 4, half-maximal inhibitory concentration: 4.64 ug/mL
Compound 4: the middle estimate sits 1.2-fold (0.07 log units) above what was measured; measured number inside the range.
By their numbers in this assay, from the lowest: compounds 4, 1, 3 and 2 (each within the scatter of the next).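

Placing (1,3-benzothiazol-2-yl)amino on the amine nitrogen, the first change tested at the linker itself, gives no step beyond the scatter in this assay: a 1.0-fold lower number from compound 1 to compound 4 (0.01 log units; within the scatter). The comparisons with the ring-substituted compounds agree, at a 1.2-fold lower number from compound 3 to compound 4 (0.08 log units; within the scatter) and a 1.4-fold lower number from compound 2 to compound 4 (0.15 log units; within the scatter). No evidence is available to explain this result. Still open, from the compounds shown here alone, is whether a longer chain or an amide at this amine nitrogen would also stay within the scatter. Also open, going by these compounds, is whether a bromo or difluoro group would do so on the ring of compound 4.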